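The source may report more compounds than this note shows. Statements on the series, on what has been measured and on what is new or still open speak of the compounds shown alone.

Measured in a functional assay on A-375 cells (Homo sapiens) for inhibition; a lower number here means a stronger inhibitor, a higher number a weaker inhibitor:
compound 1 `N#CC1CN1C(=O)Nc1ccc(Cl)c(Cl)c1` gives 5900 nM
compound 2 `CC(C)(C)NC(=O)N1CC1C#N` gives 418000 nM
compound 3 `N#CC1CN1C(=O)Nc1ccc(C(F)(F)F)cc1` gives 11800 nM

Compound 2 holds the highest number of the three. Compound 3 is nearest to it and compound 1 furthest; both gaps lie beyond the scatter, so compound 2 is the weakest inhibitor of the measured set on the shared core.

Compound 4 `CNC(=O)N1CC1C#N` differs from compound 2 by methyl in place of tert-butyl on an amide-type nitrogen. Within the data shown here, no measured pair makes a comparable change, so the size of this step has no precedent here; compound 1 and compound 3 carry aryl substituents on that nitrogen and say nothing about a swap between two alkyl groups. The expected step is small and more likely upward than downward, close to the scatter: a 1.4-fold higher number from compound 2 to compound 4 (0.16 log units; within the scatter). Compound 4 is accordingly expected at 600000 nM, within 150000 nM to 2000000 nM.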

Compound 4, half-maximal inhibitory concentration: 17000 nM
For compound 4 the middle estimate is 35-fold (1.55 log units) above the measured one; the whole stated range lies above it.
By their numbers in this assay, from the lowest: compounds 1, 3 and 4 (each within the scatter of the next, the first and the last beyond it); then compound 2.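

In this assay, methyl in place of tert-butyl on the amide-type nitrogen gives a 25-fold lower number from compound 2 to compound 4 (1.39 log units; beyond the scatter), so the choice of alkyl group at this position can move the number well beyond the scatter. The high number of compound 2 therefore goes with tert-butyl specifically, not with every alkyl group on this nitrogen.

On these data alone, how ethyl, isopropyl or a longer chain carrying an amine would read at this position stays open. The cause of the step also stays open, as no measurement shown here bears on it.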